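The compounds below may be only part of what the source reports. "The series", "measured", "known", "first", "only" and "open" are said of these compounds alone.

Of the compounds shown here, three built on a shared core have been measured in an assay on isolated protein for agonist activity at Bile acid receptor (Homo sapiens), read by AlphaScreen, with a stated time of 30 min; on this read-out higher numbers stand for an effect only at larger amounts of compound and lower numbers for an effect already at smaller amounts. Compound 1 `CCc1ccccc1-n1nc(C)c2c1NC(=O)[C@H](C)S[C@@H]2c1ccc(Oc2ccccc2)cc1` gives 1100 nM. Compound 2 `Cc1nn(-c2ccccc2Cl)c2c1C(c1ccc(Oc3ccccc3)cc1)SC(C)C(=O)N2` gives 2700 nM in this assay, and compound 3 `Cc1ccccc1-n1nc(C)c2c1NC(=O)[C@H](C)S[C@@H]2c1ccc(-c2ccco2)cc1` gives 3600 nM. Compound 1 thus stands at the lowest of the three numbers; compound 2 is its nearest neighbour and compound 3 its furthest, and both of those gaps lie beyond the usual scatter. The three measured compounds differ from one another in more than one place, so no single structural step can be read off from them.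

Compound 4 `Cc1nn(-c2ccccc2C(C)C)c2c1[C@@H](c1ccc(Oc3ccccc3)cc1)S[C@@H](C)C(=O)N2` has not yet been measured. It differs from compound 1 in one place: methyl in place of hydrogen on a saturated chain carbon bound to an aromatic carbon and a saturated chain carbon. Within the data shown here, no measured pair shows this same change, so nothing in hand tells directly how the number will move. Because compound 1 already gives 1100 nM, and the change is a single carbon on a chain that the measured set does not vary in isolation, the expectation is modest. The step is expected to be small, no change at the digits printed from compound 1 to compound 4 (within the scatter), with no direction beyond the scatter. Compound 4 is accordingly estimated at 1100 nM, with a range from 400 nM to 3000 nM.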

Compound 4, half-maximal effective concentration: 1900 nM
For compound 4 the middle estimate is 1.7-fold (0.24 log units) below the measured one, and the stated range covers the measured number.
By their numbers in this assay, from the lowest: compounds 1, 4, 2 and 3 (each within the scatter of the next, the first and the last beyond it).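

In this assay, among these compounds, the change from 2-ethylphenyl to 2-isopropylphenyl gives a 1.7-fold higher number from compound 1 to compound 4 (0.24 log units; within the scatter) and is the first change in this set that can be read on its own. The saturated chain carbon bound to an aromatic carbon and a saturated chain carbon thus takes an added methyl with no shift in the number beyond the usual scatter, so ethyl and isopropyl cannot be told apart here. The earlier compounds shown here, which differ from one another in more than one place, offered no such reading. Nothing at hand speaks to what lies behind this result.

As far as these compounds go, how far this tolerance extends at this place remains open: a tert-butyl group, a longer chain such as propyl, or a chain ending in an amine or a carboxylic acid might leave the number within the scatter or move it beyond. Also open, from the compounds shown here alone, is whether the same step from ethyl to isopropyl would read the same way on a different read-out, since this single pair rests on one assay alone.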